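Taking the aromatic methyl off compound 2

A few compounds are considered here, and "the series" means these few. Any claim that something is new, unique, unknown or untested is made for them only; others in the source may bear on it.

Of the compounds shown here, three of one shared core have been tested in a functional assay for inhibition, with Homo sapiens as the target; on this read-out higher numbers stand for weaker inhibition and lower numbers for stronger inhibition. Compound 1 `CCCc1nc(C)c2cnnc(O)n12` gives 56800 nM. Compound 2 `Cc1nc(C(C)(C)C)n2c(O)nncc12` gives 31000 nM. Compound 3 `Cc1nc(C(C)C)n2c(O)nncc12` reaches only a limit of the assay, > 48000 nM. That limit, (the limit of > 48000 nM in this assay, at which 1 of the 3 values shown sits), is the edge of what this assay reports. Of the two real numbers, compound 2 holds the lower one, and its nearest neighbour is compound 1, but a 1.8-fold lower number from compound 1 to compound 2 (0.26 log units; within the scatter), so the two cannot be ranked.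

Compound 4 `CC(C)(C)c1ncc2cnnc(O)n12` differs from compound 2 in one place: hydrogen in place of methyl on an aromatic carbon. Going by the values given here, no measured step removes a methyl from an aromatic carbon, so the bearing of the known steps is indirect. The closest is the loss of a methyl from a saturated carbon, an at least 1.5-fold higher number from compound 2 to compound 3 (0.18 log units; that floor lies within the scatter), a floor that speaks only for a weak rise. The other step to compound 3 is blind, since a step that the limit leaves unreadable from compound 1 to compound 3. The expected step in this assay is therefore small, a 1.5-fold higher number from compound 2 to compound 4 (0.16 log units; within the scatter), toward a higher number if any. Compound 4 is estimated at 45000 nM, with a range of 20000 nM to 100000 nM, and a fair chance that this assay returns only a limit.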

Compound 4, half-maximal inhibitory concentration: > 48000 nM
Compound 4: a limit, no number (the forecaster's own chance of this, stated with the estimate: 40%); middle value at least 1.0-fold (0.02 log units) from the limit.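

In this assay compound 4 gives > 48000 nM, which is a limit of the assay and not a number. Hydrogen in place of methyl on this aromatic carbon, two ring bonds from the ring atom that bears the tert-butyl group, gives an at least 1.5-fold higher number from compound 2 to compound 4 (0.18 log units; that floor lies within the scatter), so this first reading at the position shows no sign that removing the methyl strengthens inhibition, though it does not establish that the methyl is needed. The earlier compounds changed only the group on the other ring carbon, and the step at this position now ends at the same edge of the read-out as compound 3 does: the limit of > 48000 nM in this assay, at which 2 of the 4 values shown sit.

On these data alone, how far compound 4 truly lies from compound 2 remains open, and so does whether the methyl matters beyond the scatter at all. Also open, as far as these compounds go, is how an ethyl group, a chlorine atom or an amine on this aromatic carbon would compare with the methyl of compound 2, and whether the same change would read alike with propyl in place of tert-butyl.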